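Trading an Oxygen Link for Sulfur

The source may hold more compounds than are shown below. What is called first, only, known or untested is meant among the compounds shown, and "the series" means these compounds.

Compound 1, `Nc1cc(N)c2nc(-c3ccccc3)c(Oc3ccc(Cl)c(Cl)c3)nc2c1`, in a functional assay on A498 cells (Homo sapiens) for inhibition, read by sulforhodamine B assay, with a stated time of 48 h; on this read-out higher numbers stand for weaker inhibition of growth and lower numbers for stronger inhibition of growth: < 100000 nM, which is a limit of the assay and not a number.
Compound 2, `Nc1cc(N)c2nc(-c3ccccc3)c(NCc3ccc(Cl)c(Cl)c3)nc2c1`, in this assay: 32400 nM.
Compound 3, `COc1cc(CNc2nc3cc(N)cc(N)c3nc2-c2ccccc2)cc(OC)c1OC`, in this assay: 14800 nM.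

Where compound 1 stands is known only roughly: the assay reports (the limit of < 100000 nM in this assay, at which 1 of the 3 values shown sits), so no exact figure places it among the other two. Compound 2 and compound 3 each carry a benzylamino link in place of the aryl ether of compound 1, and both return measured numbers rather than a limit, numbers that on this growth read-out stand for weak inhibition.

Compound 4, `Nc1cc(N)c2nc(-c3ccccc3)c(Sc3ccc(Cl)c(Cl)c3)nc2c1`, keeps the shared core of compound 1 and alters only the linking atom: (3,4-dichlorophenyl)sulfanyl in place of 3,4-dichlorophenoxy on an aromatic carbon. Sulfur and oxygen here carry the same dichlorinated ring and the same count of acceptors, so a small change is expected at most. Since compound 1 is known only as < 100000 nM, the step in this assay from compound 1 to compound 4 is expected to be either none beyond the scatter or a modest move toward stronger inhibition, and the estimate a step that the limit leaves unreadable from compound 1 to compound 4 reflects that. Compound 4 is therefore expected to give about 45000 nM, within 12000 nM to 100000 nM.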

Compound 4, concentration for total growth inhibition: 30900 nM
The estimate for compound 4 lay 1.5-fold (0.16 log units) above the measured number, within the range that was stated.
By their numbers in this assay, from the lowest: compound 3; then compounds 4 and 2 (each within the scatter of the next).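

Compound 1 is known only through a limit of the assay, so the swap of its 3,4-dichlorophenoxy for the (3,4-dichlorophenyl)sulfanyl of compound 4 gives no step of readable size: the limit of < 100000 nM in this assay, at which 1 of the 4 values shown sits.

The compounds shown leave open whether the sulfur link and the oxygen link differ at all in this assay.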